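Swapping the pyridinyl ring for a trimethylpyrazolyl ring

A few compounds are considered here, and "the series" means these few. Any claim that something is new, unique, unknown or untested is made for them only; others in the source may bear on it.

Compound 1 `CC(NC(=O)COc1cc(C(F)(F)F)c2c(-c3ccccc3)nn(C)c2n1)c1ccccn1`: in a functional assay on isolated protein for antagonist activity at Orexin receptor type 2 (Homo sapiens), read by fluorescence, FLIPR and calcium flux, with a stated time of 1 h (on this read-out lower numbers stand for stronger inhibition and higher numbers for weaker inhibition), compound 1 gives "not active" (no number reported), with no number reported.
Compound 2 `CC(NC(=O)COc1cc(C(F)(F)F)c2c(-c3ccccc3)nn(C)c2n1)c1cccnc1`: in this assay compound 2 gives 582 nM.

The two measured compounds share one core and differ only in the aromatic ring carried on the ethyl group that sits on the amide nitrogen. Compound 1 returned no number in this assay, so it cannot be placed on a scale. Going by the values given here, compound 2 is therefore the only measured number here and the sole anchor for what follows.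

Compound 3 `Cc1nn(C)c(C)c1[C@H](C)NC(=O)COc1cc(C(F)(F)F)c2c(-c3ccccc3)nn(C)c2n1` keeps everything in compound 2 except that ring: 1-(1,3,5-trimethyl-1H-pyrazol-4-yl)ethyl in place of 1-(pyridin-3-yl)ethyl on an amide-type nitrogen. Among the compounds with values here, no measured pair shows what such an exchange does in this assay, so any expectation rests on compound 2 alone and carries a wide uncertainty. The step from compound 2 to compound 3 is expected to be a 1.5-fold lower number from compound 2 to compound 3 (0.16 log units; within the scatter), a shift that would stay within the usual scatter rather than a clear gain or loss. For compound 3 the estimate is 400 nM, with a range from 80 nM to 2000 nM.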

Compound 3, inhibition constant: 10 nM
Beside the measured number, compound 3's estimate is 40-fold (1.60 log units) above it; measured number outside the range, below it.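

The ring carried on the ethyl group of the amide-type nitrogen turns out to have a large effect on the result in this assay: placing 1-(1,3,5-trimethyl-1H-pyrazol-4-yl)ethyl there in place of 1-(pyridin-3-yl)ethyl gives a 58-fold lower number from compound 2 to compound 3 (1.76 log units; beyond the scatter), with the rest of the molecule untouched. Going by these compounds alone, until this result, the position had only one number attached to it, so the size of the effect that a change here could have was unknown; now a single exchange at this site is seen to move the read-out well beyond the usual scatter. No measurement shown here explains this gain, and the reason for it remains unknown.

The exchange also changes several things at once, namely the ring size, the hetero atoms, the methyl groups and the defined stereocentre, and the compounds shown do not separate their contributions. A comparison with 1-(1H-pyrazol-4-yl)ethyl, which lacks the methyl groups, and with the mirror-image form of compound 3 would show how much of the step each of these features carries.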